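Compound 4: swapping the group on the carbonyl carbon

A few compounds are considered here, and "the series" means these few. Any claim that something is new, unique, unknown or untested is made for them only; others in the source may bear on it.

In a functional assay on MCF7 cells (Homo sapiens) for inhibition, read by MTT assay, with a stated time of 4 days (a higher number here means a weaker inhibitor, a lower number a stronger inhibitor), compound 3 `COc1cc(NC(C)CCCNC(=O)NNC(=O)N(CCO)CCO)c2ncccc2c1` gives 29000 nM, within the scatter of compound 2 `COc1cc(NC(C)CCCNC(=O)NN)c2ncccc2c1` at 16000 nM. Compound 1 `COc1cc(NC(C)CCCNC(=O)NNC(=O)NCCCCCO)c2ncccc2c1` gives 4000 nM. Compound 4 `COc1cc(NC(C)CCCNC(=O)NNC(=O)NCCCO)c2ncccc2c1` carries (3-hydroxypropyl)amino in place of bis(2-hydroxyethyl)amino on a carbonyl carbon. The closest measured precedent changes the same place, a 7.3-fold higher number from compound 1 to compound 3 (0.86 log units; beyond the scatter), with compound 1 holding (5-hydroxypentyl)amino. Two further steps give context: a 4.0-fold higher number from compound 1 to compound 2 (0.60 log units; beyond the scatter) and a 1.8-fold higher number from compound 2 to compound 3 (0.26 log units; within the scatter). Within the data shown here, no measured compound has the shorter chain, so only part of the precedent is expected to carry over, in reverse. The expected step is a 3.2-fold lower number from compound 3 to compound 4 (0.51 log units; beyond the scatter). For compound 4 the estimated value is 9000 nM, with an expected range of 3500 nM to 24000 nM.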

Compound 4, half-maximal inhibitory concentration: 13000 nM
Beside the measured number, compound 4's estimate is 1.4-fold (0.16 log units) below it, and the stated range covers the measured number.
By their numbers in this assay, from the lowest: compound 1; then compounds 4, 2 and 3 (each within the scatter of the next, the first and the last beyond it).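

On the carbonyl carbon, (3-hydroxypropyl)amino in place of bis(2-hydroxyethyl)amino gives a real gain (a 2.2-fold lower number from compound 3 to compound 4 (0.35 log units; beyond the scatter)), so compound 3 now sits beyond the scatter of both compounds carrying a single hydroxyalkyl chain. That gain does not separate compound 4 from the uncapped compound 2 (a 1.2-fold lower number from compound 2 to compound 4 (0.09 log units; within the scatter)). Chain length counts here, on this pair alone: the shorter chain gives up most of the advantage of compound 1 (a 3.3-fold higher number from compound 1 to compound 4 (0.51 log units; beyond the scatter)).

No measurement shown explains these differences. Open, as far as these compounds go, is whether a longer chain than (5-hydroxypentyl)amino, or an amine or a carboxylic acid in place of the hydroxy, would lower the number further.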